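Thiophene in place of a methylphenyl ring at the biaryl position

The source may report more compounds than this note shows. Statements on the series, on what has been measured and on what is new or still open speak of the compounds shown alone.

Measured compounds in an assay on CHO cells for displacement of a labelled ligand from Alpha-2B adrenergic receptor (Homo sapiens); a higher number here means a weaker inhibitor, a lower number a stronger inhibitor:
compound 1 `Cc1ccc(-c2ccccc2OC(C)C2=NCCN2)cc1` gives 398 nM
compound 2 `CC(Oc1ccccc1-c1ccccc1O)C1=NCCN1` gives 1000 nM
compound 3 `CC(Nc1ccccc1-c1ccccc1)C1=NCCN1` gives 1150 nM

Among the three measured compounds, compound 1 holds the lowest number in this assay; compound 2 stands at a higher number, and compound 3 at a higher number still. Among the compounds with values here, the one measured step that changes the ring hanging from the shared core is a 2.5-fold higher number from compound 1 to compound 2 (0.40 log units; beyond the scatter), a modest weakening. Compound 3 is not related to the others by a single change and only shows that an aniline-linked biphenyl sits at a weaker number than compound 1.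

Compound 4 `CC(Oc1ccccc1-c1cccs1)C1=NCCN1` is not yet measured. Relative to compound 1 the change is thiophen-2-yl in place of 4-methylphenyl on an aromatic carbon. Within the data shown here, only the step from compound 1 to compound 2 bears on it, and that step was modest. A smaller aromatic ring with one hetero atom is expected to behave roughly like the hydroxyphenyl exchange, so a modest weakening or no step beyond the scatter is expected, with the estimated step being a 1.6-fold higher number from compound 1 to compound 4 (0.20 log units; within the scatter). Compound 4 is therefore estimated at 630 nM, in the range 250 nM to 1600 nM.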

Compound 4, inhibition constant: 214 nM
For compound 4 the middle estimate is 2.9-fold (0.47 log units) above the measured one, and the stated range ends above it.
By their numbers in this assay, from the lowest: compounds 4 and 1 (each within the scatter of the next); then compounds 2 and 3 (each within the scatter of the next).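

In this assay, the ring on the aromatic carbon ortho to a group of 8 heavy atoms can shrink from the six-membered 4-methylphenyl to the five-membered thiophen-2-yl with no readable change (with thiophen-2-yl entering, a 1.9-fold lower number from compound 1 to compound 4 (0.27 log units; within the scatter)). The same thiophen-2-yl in place of 2-hydroxyphenyl gives a step beyond the scatter (there, a 4.7-fold lower number from compound 2 to compound 4 (0.67 log units; beyond the scatter)), so among these three rings 2-hydroxyphenyl alone stands apart, and replacing the 4-methylphenyl ring does not in itself cost binding. Nothing at hand accounts for either step.

From the compounds shown here alone, it remains open whether the methyl of compound 1 matters, which a plain phenyl ring would show, and how thiophen-3-yl or furan-2-yl would compare at this place. Also open, going by these compounds, is whether an amine or a carboxylic acid on the ring would track compound 2 or compound 4.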